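The source may hold more compounds than are shown below. What is called first, only, known or untested is meant among the compounds shown, and "the series" means these compounds.

Compound 1, `Nc1nccc(-c2cc(OC3COC3)c3c(N)n[nH]c3c2)n1`, and compound 2, `CC(C)Oc1cc(-c2ccnc(N)n2)cc2[nH]nc(N)c12`, share one core and differ only at the oxygen on the aromatic ring. In a physicochemical assay for solubility, read by LC-MS, in phosphate buffer, measured as kinetic solubility, with a stated time of 24 h, at 25 degrees C, at pH 7.4 (a lower number here means a less soluble compound, a higher number a more soluble compound), compound 1 gives 383000 nM, and compound 2 gives 354000 nM. The step of a 1.1-fold lower number from compound 1 to compound 2 (0.03 log units; within the scatter) keeps the two compounds within the scatter of each other, so on the numbers shown compound 2 stands level with compound 1 rather than apart from it.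

Compound 3, `Nc1nccc(-c2cc(Oc3ccccc3)c3c(N)n[nH]c3c2)n1`, takes the next step on the same oxygen: phenyl in place of isopropyl on an oxygen on an aromatic ring. For the measured compounds named here, the only measured step that bears on this position is a 1.1-fold lower number from compound 1 to compound 2 (0.03 log units; within the scatter), which exchanged one small group for another and moved nothing beyond the scatter. Going by the values given here, no measured step brings a phenyl onto that oxygen, so the exchange in compound 3 is not directly tested by the data at hand.

Among the compounds with values here, with the one relevant step flat, and the new group larger in its count of atoms than either group measured before it, compound 3 is expected to give a number lower than compound 2, the expected step being a 3.0-fold lower number from compound 2 to compound 3 (0.47 log units; beyond the scatter). Compound 3 is therefore estimated at 120000 nM, within a range from 30000 nM to 350000 nM.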

Compound 3, solubility: 117000 nM
The estimate for compound 3 lay 1.0-fold (0.01 log units) above the measured number, and the stated range covers the measured number.
By their numbers in this assay, from the lowest: compound 3; then compounds 2 and 1 (each within the scatter of the next).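

The number read in this assay now moves with the group on the oxygen, where the earlier exchange of oxetan-3-yl for isopropyl had stayed within the scatter: phenyl in place of isopropyl gives a 3.0-fold lower number from compound 2 to compound 3 (0.48 log units; beyond the scatter) and phenyl in place of oxetan-3-yl gives a 3.3-fold lower number from compound 1 to compound 3 (0.52 log units; beyond the scatter) on the same shared core. This position therefore responds to the group it carries, and both steps, modest but beyond the scatter, run the same way from two starting groups that stand level with each other. Phenyl brings a six-membered aromatic ring of carbon only where isopropyl brought no ring, but no measurement on hand accounts for the drop.

The compounds shown do not separate the aromatic ring from the larger count of heavy atoms, a question that a saturated carbon ring such as cyclohexyl would address. They also leave open whether a phenyl carrying an amine or a carboxylic acid would stay with compound 3 or move back towards compounds 1 and 2.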